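From methyl to phenyl on a carbonyl carbon

The source may report more compounds than this note shows. Statements on the series, on what has been measured and on what is new or still open speak of the compounds shown alone.

Measured so far in an ADME assay on MRC5 cells (Homo sapiens) for cytotoxicity, read by MTT assay, with a stated time of 72 h; a higher number here means a weaker inhibitor, a lower number a stronger inhibitor:
- Compound 1 `Cc1ccc(C(=O)Nc2nnc(-c3ccc(O)c(O)c3)s2)cc1` gives 27100 nM
- Compound 2 `O=C(Nc1nnc(-c2ccc(O)c(O)c2)s1)c1ccc(Cl)cc1` gives 30600 nM
- Compound 3 `CC(=O)Nc1nnc(-c2ccc(O)c(O)c2)s1` gives 58600 nM

Compound 3 carries a methyl where the other two carry a ring, and it lies close to both. The measured steps are a 2.2-fold higher number from compound 1 to compound 3 (0.33 log units; beyond the scatter) and a 1.9-fold higher number from compound 2 to compound 3 (0.28 log units; within the scatter). Swapping the group on the ring changes little, with a 1.1-fold higher number from compound 1 to compound 2 (0.05 log units; within the scatter).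

Compound 4 `O=C(Nc1nnc(-c2ccc(O)c(O)c2)s1)c1ccccc1` has phenyl in place of methyl on a carbonyl carbon. This runs opposite to those two ring-to-methyl steps, so a lower number of similar size is expected. The expected change is a 2.0-fold lower number from compound 3 to compound 4 (0.31 log units; beyond the scatter) in this assay. Compound 4 is estimated at 29000 nM, with an expected range of 17000 nM to 50000 nM.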

Compound 4, half-maximal inhibitory concentration: 27400 nM
Beside the measured number, compound 4's estimate is 1.1-fold (0.02 log units) above it; low and high end bracket the measured number.
By their numbers in this assay, from the lowest: compounds 1, 4, 2 and 3 (each within the scatter of the next, the first and the last beyond it).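

In this assay, the plain phenyl ring of compound 4 is enough to set it apart from the methyl of compound 3 (a 2.1-fold lower number from compound 3 to compound 4 (0.33 log units; beyond the scatter)). Hydrogen in place of chloro (a 1.1-fold lower number from compound 2 to compound 4 (0.05 log units; within the scatter)) or in place of methyl (a 1.0-fold higher number from compound 1 to compound 4 (0.00 log units; within the scatter)) on the aromatic carbon stays within the scatter, so among these compounds the group on the ring makes no readable difference. Nothing measured here bears on the reason for this result.

On these data alone, it remains open whether a cyclohexyl ring or a longer chain on the carbonyl carbon, or an amine on the phenyl ring, would group with the ring compounds or with compound 3.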